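Replacing the hydroxy group of compound 3 with a butyl chain

The source may hold more compounds than are shown below. What is called first, only, known or untested is meant among the compounds shown, and "the series" means these compounds.

Of the compounds shown here, three built on one shared core have been tested in a functional assay on the whole organism for inhibition, with Rattus norvegicus as the target; a higher number here means that more compound is needed for the effect, a lower number that less compound is needed. Compound 1 `CC1CC/C(=N\Nc2cccc(Cl)c2)c2ncc(C(=O)O)c(=O)n21` gives 0.6 umol/kg, and compound 2 `CC1CC/C(=N\Nc2cccc(Br)c2)c2ncc(C(=O)O)c(=O)n21` gives 0.4 umol/kg; the step of a 1.5-fold lower number from compound 1 to compound 2 (0.18 log units; within the scatter) is small. Compound 3 `CC1CC/C(=N\Nc2ccc(O)cc2)c2ncc(C(=O)O)c(=O)n21` gives 1.7 umol/kg, the highest of the three numbers, so it is the one needing the most material for the effect. The steps of a 2.8-fold higher number from compound 1 to compound 3 (0.45 log units; beyond the scatter) and a 4.3-fold higher number from compound 2 to compound 3 (0.63 log units; beyond the scatter) both raised the number once the halogen-bearing ring was exchanged for the hydroxy-bearing ring.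

Compound 4 `CCCCc1ccc(N/N=C2\CCC(C)n3c2ncc(C(=O)O)c3=O)cc1` has not yet been measured. It differs from compound 3 in one place: butyl in place of hydroxy on an aromatic carbon. Going by the values given here, no measured step tests this exact change, so the expectation rests only on the observation that compound 1 and compound 2, which carry no hydroxy group, gave lower numbers than compound 3. A butyl chain is nonetheless a different kind of group from a halogen, and it sits para to a large group, so the outcome is uncertain. On balance a modest fall in the number is expected, as the step of a 1.9-fold lower number from compound 3 to compound 4 (0.28 log units; within the scatter). Compound 4 is therefore estimated at 0.9 umol/kg, with a plausible range from 0.3 umol/kg to 3 umol/kg.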

Compound 4, dose for 50% inhibition: 7.8 umol/kg
Beside the measured number, compound 4's estimate is 8.7-fold (0.94 log units) below it; the measured number lies above the stated range.
By their numbers in this assay, from the lowest: compounds 2 and 1 (each within the scatter of the next); then compound 3; then compound 4.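

In this assay, the change at this place on the ring, para to a large group, raises the number (a 4.6-fold higher number from compound 3 to compound 4 (0.66 log units; beyond the scatter)), so more compound is needed for the effect once butyl replaces hydroxy. The earlier compounds shown here had hinted that losing the hydroxy might lower the number, but compound 1 and compound 2 differ from compound 3 both in the group and in where it sits on the ring, whereas this single change shows that removing the hydroxy in favour of butyl does not by itself bring the number down. The swap puts four carbons in place of one oxygen and also removes a hydrogen-bond donor and acceptor, and no measured property of these compounds is available to say which of these differences matters.

A shorter chain such as methyl or ethyl at this same place would show whether the rise grows with chain length, while a methoxy group would show what happens when the oxygen stays but its hydrogen is gone. From the compounds shown here alone, whether chloro or bromo would keep their low numbers at this place, rather than where they sit in compound 1 and compound 2, also remains open.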